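Methyl in Place of Methoxy: An Untested Analogue

The compounds below may be only part of what the source reports. "The series", "measured", "known", "first", "only" and "open" are said of these compounds alone.

Compound 1 `COc1ccc(C2=Nn3c(nnc3C(C)c3ccc(-c4ccccc4)c(F)c3)SC2)cc1`: 4400 nM
Compound 2 `COc1ccc2cc(C(C)c3n[nH]c(=S)n3N)ccc2c1`: 20200 nM

In a functional assay on HCT-116 cells (Homo sapiens) for inhibition, read by sulforhodamine B assay, with a stated time of 72 h (a lower number here means a stronger inhibitor, a higher number a weaker inhibitor), compound 1 gives 4400 nM, the lowest of the two numbers. Compound 2 gives 20200 nM, a higher number, beyond the scatter. Compound 3 `Cc1ccc(C2=Nn3c(nnc3C(C)c3ccc(-c4ccccc4)c(F)c3)SC2)cc1` differs from compound 1 by methyl in place of methoxy on an aromatic carbon. No comparable change is present among the measured compounds, so the step is expected to be small, within the scatter, with no clear direction. Compound 3 is estimated at 5000 nM, with a range from 2000 nM to 15000 nM, and the expected step of a 1.1-fold higher number from compound 1 to compound 3 (0.06 log units; within the scatter) stays within the scatter.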

Compound 3, half-maximal inhibitory concentration: 4800 nM
Compound 3: middle estimate off by 1.0-fold (0.02 log units), on the high side, within the range that was stated.
By their numbers in this assay, from the lowest: compounds 1 and 3 (each within the scatter of the next); then compound 2.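

In this assay, within the data shown here, going from 4-methoxyphenyl to 4-methylphenyl gives a 1.1-fold higher number from compound 1 to compound 3 (0.04 log units; within the scatter), the first comparison here of compounds that differ in one place. At this position on the core of compound 1, the methoxy group can therefore give way to methyl, with one hydrogen-bond acceptor fewer, without a change that can be told from the scatter. Nothing measured here addresses why the two compounds read alike. The compounds shown leave open whether a hydroxyl, an amine, a carboxylic acid or a longer chain such as butoxy at this position would move the number beyond the scatter.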